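Trimming a chalcone: solubility expectation for compound 3

The source may report more compounds than this note shows. Statements on the series, on what has been measured and on what is new or still open speak of the compounds shown alone.

Measured compounds:
- compound 1, `COc1ccc(C(=O)/C=C/c2ccc(OCCNc3ccnc4cc(Cl)ccc34)c(OC)c2)c(OC)c1`: 3.1 ug/mL
- compound 2, `COc1cc(/C=C/C(C)=O)ccc1OCc1cn(-c2ccnc3cc(Cl)ccc23)nn1`: 3.1 ug/mL

Of the compounds shown here, two share the same chloro-substituted core and have been measured in a physicochemical assay for solubility, in phosphate buffer, at pH 6.5; on this read-out higher numbers stand for higher solubility and lower numbers for lower solubility. Compound 1 gives 3.1 ug/mL in this assay. Compound 2, which links the core through a different connector and ends in a small methyl ketone, gives 3.1 ug/mL; the two values are level within the scatter, so neither can be called the more soluble.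

Compound 3, `COc1cc(/C=C/C(C)=O)ccc1OCCNc1ccnc2cc(Cl)ccc12`, has not yet been measured. It differs from compound 1 in one place: methyl in place of 2,4-dimethoxyphenyl on a carbonyl carbon. Cut one bond further out, the change reads (2,4-dimethoxyphenyl)carbonyl to acetyl, so compound 3 loses a whole aromatic ring and keeps the rest of compound 1 intact.

Going by the values given here, no measured pair shows this exact change. Since compound 2, which also carries the acetyl end, sits at 3.1 ug/mL, a large shift is not expected. A modest step upward in this assay is expected, a 2.6-fold higher number from compound 1 to compound 3 (0.41 log units; beyond the scatter), with a wide band. Compound 3 is estimated at 8 ug/mL, between 2.5 ug/mL and 30 ug/mL.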

Compound 3, solubility: 6.3 ug/mL
Beside the measured number, compound 3's estimate is 1.3-fold (0.10 log units) above it; the range from low to high includes it.
By their numbers in this assay, from the lowest: compounds 1 and 2 (each within the scatter of the next); then compound 3.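

In this assay, putting methyl in place of 2,4-dimethoxyphenyl on a carbonyl carbon gives a 2.0-fold higher number from compound 1 to compound 3 (0.31 log units; beyond the scatter), the first step measured at this position. The step is modest but lies beyond the scatter, so this single change can be read as a real difference between the two compounds. The structural change is much larger than the step might suggest: 10 heavy atoms, including one six-membered aromatic ring and 2 hydrogen-bond acceptors, leave and 1 heavy atom enters, yet the number rises only modestly. No measurement here explains why the number moves, so the step stands as an observation and not as an account of its cause.

This one pair cannot separate the removal of the aromatic ring from the removal of its methoxy groups, a question that a plain phenyl on the same carbonyl carbon could address. It also leaves open how the number would respond if the methyl gave way to a longer chain, an amine or a carboxylic acid.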